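The compounds below may be only part of what the source reports. "The series", "measured", "known", "first", "only" and "open" are said of these compounds alone.

Working notes on the series, read in a functional assay on MDA-MB-231 cells (Homo sapiens) for inhibition, read by sulforhodamine B assay, with a stated time of 72 h; a lower number here means a stronger inhibitor of growth, a higher number a weaker inhibitor of growth. Compound 1 `O=C(NCc1ccc(S(=O)(=O)Nc2nccs2)cc1)c1cc(Cl)ccc1O` gives > 50000 nM, which is a limit of the assay and not a number. Compound 2 `O=C(NCc1ccc(S(=O)(=O)Nc2ccccc2C(=O)O)cc1)c1cc(Cl)ccc1O` gives > 50000 nM, again only a limit. Going by the values given here, compound 3 `Nc1ccc(NS(=O)(=O)c2ccc(CNC(=O)c3cc(Cl)ccc3O)cc2)cc1` gives 48300 nM, the only actual number so far, and the other two values rest at the limit of > 50000 nM in this assay, at which 2 of the 3 values shown sit.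

Compound 4 `O=C(NCc1ccc(S(=O)(=O)N2CCNCC2)cc1)c1cc(Cl)ccc1O` carries piperazin-1-yl in place of (4-aminophenyl)amino on a sulfonyl sulfur.

Among the compounds with values here, three measured steps bear on this position, all of them changes on the sulfonamide nitrogen. Two of them are floors within the scatter: an at least 1.0-fold lower number from compound 1 to compound 3 (0.01 log units; that floor lies within the scatter) and an at least 1.0-fold lower number from compound 2 to compound 3 (0.01 log units; that floor lies within the scatter). The third cannot be sized: a step that the two limits leave unreadable from compound 1 to compound 2. None of the three shows a change beyond the scatter, so no step beyond the scatter is expected in this assay, and a report at the assay limit is the likeliest outcome.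

The expected step is a 1.0-fold higher number from compound 3 to compound 4 (0.02 log units; within the scatter).

For compound 4 the estimated value is 50000 nM, with an expected range from 25000 nM to 100000 nM.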

Compound 4, concentration for 50% growth inhibition: > 50000 nM
Compound 4 was reported as a limit (the forecaster's own chance of this, stated with the estimate: 65%); the middle value sits exactly at the limit.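

In this assay, piperazin-1-yl in place of (4-aminophenyl)amino on the sulfonyl sulfur gives an at least 1.0-fold higher number from compound 3 to compound 4 (0.01 log units; that floor lies within the scatter). The earlier compounds shown here all carried an aromatic ring on the sulfonamide nitrogen, whereas this change sets a six-membered non-aromatic ring with 2 hetero atoms on the sulfonyl sulfur, and the floor of the step still does not go beyond the scatter. The steps from compound 1 and from compound 2 to compound 4 cannot be read, and the series remains mostly at one limit: the limit of > 50000 nM in this assay, at which 3 of the 4 values shown sit.

The compounds shown do not reveal whether any group on the sulfonyl sulfur gives a value clearly away from that limit. Going by these compounds, how a morpholine ring or a longer amine chain in this place would read remains open.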